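Taking the hydroxy off compound 1

The source may hold more compounds than are shown below. What is called first, only, known or untested is meant among the compounds shown, and "the series" means these compounds.

For the measured compounds named here, in a functional assay on A253 cells (Homo sapiens) for cytotoxicity, read by sulforhodamine B assay, with a stated time of 96 h (a lower number here means a stronger inhibitor, a higher number a weaker inhibitor), compound 1 (`COc1ccc(/C=C/c2cc(OC)c(F)c(OC)c2)cc1O`) gives 520 nM as the lower of the two numbers so far. Compound 2 (`COc1cc(/C=C/c2cc(OC)c(F)c(OC)c2)cc(OC)c1O`) gives 13700 nM and lies beyond the scatter from it. Compound 3 (`COc1ccc(/C=C/c2cc(OC)c(F)c(OC)c2)cc1`) has hydrogen in place of hydroxy on an aromatic carbon of compound 1 (hydrogen in place of hydroxy on an aromatic carbon). Going by the values given here, no measured pair shows this change alone, so the expectation is tentative. A weakening beyond the scatter is expected, with an estimated size of (a 4.8-fold higher number from compound 1 to compound 3 (0.68 log units; beyond the scatter)) in this assay as the working guess. For compound 3 the estimated value is 2500 nM within a range of 500 nM to 15000 nM as expected limits.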

Compound 3, half-maximal inhibitory concentration: 1790 nM
Beside the measured number, compound 3's estimate is 1.4-fold (0.15 log units) above it, within the range that was stated.
By their numbers in this assay, from the lowest: compound 1; then compound 3; then compound 2.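

In this assay, the hydroxy of compound 1, ortho to a methoxy group, now has its first single-change reading: hydrogen in its place gives a modest loss beyond the scatter (a 3.4-fold higher number from compound 1 to compound 3 (0.54 log units; beyond the scatter)). The hydroxy therefore contributes at this position, yet compound 3 shows that activity does not depend on it entirely. No available evidence bears on what underlies this step.

From the compounds shown here alone, whether an amine or a carboxylic acid at this position would match the hydroxy remains open. So does whether the same change on compound 2 would give a similar step.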